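Replacing the Pyrrolidinylcarbonyl Group with a Methoxyethyl Chain

This account rests on a few compounds, and the source may have more. Where it says the series, first, only, none or still open, it means among the compounds named here.

Measured compounds:
- compound 1 `CN(C)S(=O)(=O)NC[C@@H]1CCCc2cc(S(=O)(=O)c3cccc(F)c3)ccc21`: 2 nM
- compound 2 `O=C(NC[C@@H]1CCCc2cc(S(=O)(=O)c3cccc(F)c3)ccc21)c1ncc[nH]1`: 15.9 nM
- compound 3 `O=C(NC[C@@H]1CCCc2cc(S(=O)(=O)c3cccc(F)c3)ccc21)[C@H]1CCCN1`: 0.631 nM

In an assay on isolated protein for displacement of a labelled ligand from 5-hydroxytryptamine receptor 6 (Homo sapiens) (a higher number here means a weaker inhibitor, a lower number a stronger inhibitor), compound 3 gives the lowest number of the three, with compound 1 nearest and compound 2 furthest from it. All three share the same core and differ only in the group carried on the amine nitrogen. The step of a 3.2-fold lower number from compound 1 to compound 3 (0.50 log units; beyond the scatter) and the step of a 25-fold lower number from compound 2 to compound 3 (1.40 log units; beyond the scatter) both show that this group moves the read-out beyond the scatter, and the step of an 8.0-fold higher number from compound 1 to compound 2 (0.90 log units; beyond the scatter) shows the same in the other direction.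

Compound 4 `COCCNC[C@@H]1CCCc2cc(S(=O)(=O)c3cccc(F)c3)ccc21` is not yet measured. Its difference from compound 3 is 2-methoxyethyl in place of (pyrrolidin-2-yl)carbonyl on an amine nitrogen. Going by the values given here, no measured step exchanges a carbonyl-bearing group on that nitrogen for a plain alkyl chain, so the measured steps bear on it only by showing that changes at this position shift the number by a modest to large amount. With the carbonyl gone and the ring gone, an expected move away from the lowest number seems more likely than a further improvement, though the size is uncertain. Compound 4 is therefore estimated at 3 nM, within a range of 0.6 nM to 15 nM, which means an expected step of a 4.8-fold higher number from compound 3 to compound 4 (0.68 log units; beyond the scatter).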

Compound 4, inhibition constant: 0.251 nM
Compound 4: middle estimate off by 12-fold (1.08 log units), on the high side; measured number outside the range, below it.
By their numbers in this assay, from the lowest: compound 4; then compound 3; then compound 1; then compound 2.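

Compound 4 is the only one of the four whose amine nitrogen carries a plain chain rather than a carbonyl or sulfamoyl group, and in this assay this exchange gives a 2.5-fold lower number from compound 3 to compound 4 (0.40 log units; beyond the scatter) instead of a loss. At this position, therefore, a low number does not require the (pyrrolidin-2-yl)carbonyl group, with its ring, its carbonyl and its defined stereocentre, and the entering 2-methoxyethyl group brings no ring and no hydrogen-bond donor of its own. The chain also outdoes the other two groups, with an 8.0-fold lower number from compound 1 to compound 4 (0.90 log units; beyond the scatter) against dimethylsulfamoyl and a 63-fold lower number from compound 2 to compound 4 (1.80 log units; beyond the scatter) against (1H-imidazol-2-yl)carbonyl, which makes compound 4 the strongest of the four in this assay by steps all beyond the scatter.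

The compounds shown leave open whether the oxygen of the 2-methoxyethyl chain matters, a question that a plain butyl chain, a longer ether chain or a chain ending in an amine on the same nitrogen would address. Nothing given here explains why the plain chain gives the lowest number.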